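Methyl to chloro on two related cores

This account rests on a few compounds, and the source may have more. Where it says the series, first, only, none or still open, it means among the compounds named here.

Compound 1 `C=C1C(=O)[C@]23C[C@@]1(O)CC[C@H]2c1ccc(O)c(C)c1[C@@H]3Cn1cc(-c2ccc(Cl)cc2)nn1` and compound 2 `C=C1C(=O)[C@]23C[C@@]1(O)CC[C@H]2c1ccc(O)c(C)c1[C@@H]3Cn1cc(-c2ccc(C)cc2)nn1` share one core and differ only in a group on the outer phenyl ring. In a functional assay on SMMC-7721 cells (Homo sapiens) for cytotoxicity, read by MTT assay, with a stated time of 4 days (on this read-out lower numbers stand for stronger inhibition and higher numbers for weaker inhibition), compound 1 gives 670 nM, and compound 2 gives 920 nM. The change chloro in place of methyl on an aromatic carbon produced a 1.4-fold lower number from compound 2 to compound 1 (0.14 log units; within the scatter). Compound 3 `C=C1C[C@]23C[C@@]1(O)CC[C@H]2c1cc(Br)c(O)c(C)c1[C@@H]3Cn1cc(-c2ccc(C)cc2)nn1` carries a different core; how the two cores differ is not broken down here. In this assay compound 3 reaches only a limit of the assay, > 20000 nM. That value is the limit of > 20000 nM in this assay, at which 1 of the 3 values shown sits. Compound 4 `C=C1C[C@]23C[C@@]1(O)CC[C@H]2c1cc(Br)c(O)c(C)c1[C@@H]3Cn1cc(-c2ccc(Cl)cc2)nn1` has not yet been measured. It relates to compound 3 as compound 1 relates to compound 2: chloro in place of methyl on an aromatic carbon, and the place is described in the same words, so this counts as the same kind of change on a different core. Because a 1.4-fold lower number from compound 2 to compound 1 (0.14 log units; within the scatter) stayed within the scatter, the new step is expected to be small as well, a step that the limit leaves unreadable from compound 3 to compound 4. Compound 4 is therefore expected to give 25000 nM, between 10000 nM and 60000 nM, and most likely again only a limit.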

Compound 4, half-maximal inhibitory concentration: 19100 nM
For compound 4 the middle estimate is 1.3-fold (0.12 log units) above the measured one; the range from low to high includes it.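

Replacing 4-methylphenyl with 4-chlorophenyl on the second core gives an at least 1.0-fold lower number from compound 3 to compound 4 (0.01 log units; that floor lies within the scatter) in this assay, and that floor does not show a step larger than the usual scatter. Compound 3 has only a limit of the assay, > 20000 nM, rather than a true number, so the real size of the step could be larger than this floor: the limit of > 20000 nM in this assay, at which 1 of the 4 values shown sits. The result shows no sign that the change acts differently on the second core, but it does not prove that the change carries over with the same size, and the comparison between the two cores stays unsettled: the same change on two cores in this assay, a 1.4-fold lower number (0.14 log units; within the scatter) from compound 2 to compound 1 and an at least 1.0-fold lower number (0.01 log units; that floor lies within the scatter) from compound 3 to compound 4; the limit leaves it open whether they differ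

The compounds shown leave open how other groups at this place on the outer phenyl ring would behave, for example fluoro, methoxy or an amine. They also leave open what the core alone contributes, as no pair shown differs only in the core while keeping the same group on the outer phenyl ring.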